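A Hydroxy-to-Methoxy Step in Cell Growth Inhibition

The source may report more compounds than this note shows. Statements on the series, on what has been measured and on what is new or still open speak of the compounds shown alone.

Measured compounds:
compound 1, `COc1cc(Cl)cc(-c2nn(-c3cccc(NC(=O)c4cccc(C(F)(F)F)c4)c3)cc2-c2ccncc2)c1`, 92.4%;
compound 2, `O=C(Nc1cccc(-n2cc(-c3ccncc3)c(-c3cc(O)cc(Cl)c3)n2)c1)c1cc(C(F)(F)F)cc(C(F)(F)F)c1`, 61.8%.

In a functional assay on Malme-3M cells (Homo sapiens) for inhibition, read by sulforhodamine B assay, with a stated time of 48 h, tested at 10 uM (a higher number here means a weaker effect of the compound at the concentration tested, a lower number a stronger effect), compound 2 gives 61.8%, the lowest of the two numbers and so the stronger effect at the tested concentration. In this assay compound 1 gives 92.4%, a number higher than that of compound 2 by a gap beyond the usual scatter. Among the measured compounds shown here, these two compounds differ in more than one place, so their values show only that compound 2 acts more strongly here, not what any single change did.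

Compound 3, `COc1cc(Cl)cc(-c2nn(-c3cccc(NC(=O)c4cc(C(F)(F)F)cc(C(F)(F)F)c4)c3)cc2-c2ccncc2)c1`, is compound 2 with one alteration: methyl in place of hydrogen on an oxygen on an aromatic ring. Compound 3 thus carries the same methoxy as compound 1, which gave 92.4%, while the rest of compound 3 matches compound 2. For the measured compounds named here, no step between measured compounds isolates this change. The step is expected to be a number 18.2 percentage points higher from compound 2 to compound 3 (beyond the scatter), upward toward a weaker effect and probably beyond the scatter. Compound 3 is estimated at 80%, within 58% to 100%.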

Compound 3, a percentage reported as activity, at one concentration (the size of the read-out at that concentration, not a potency): 104%
For compound 3 the middle estimate is 24 percentage points below the measured one; the whole stated range lies below it.
By their numbers in this assay, from the lowest: compound 2; then compound 1; then compound 3.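

In this assay, replacing hydroxy with methoxy on the 3-chloro-5-hydroxyphenyl group, with the rest of the molecule unchanged, gives a number 42.2 percentage points higher from compound 2 to compound 3 (beyond the scatter), so this single change moves the read-out toward a weaker effect. Placing trifluoromethyl on an aromatic carbon in place of hydrogen, with the methoxy already present, gives a number 11.6 percentage points higher from compound 1 to compound 3 (beyond the scatter), a smaller move in the same direction, so this group does not strengthen the effect in the methoxy series. No measurement here explains why either step occurs.

On these data alone, it remains open whether the stronger effect needs the hydroxy itself or whether an amine or a carboxylic acid in its place would give a similar result. Also open, as far as these compounds go, is how the hydroxy compound would respond if its added trifluoromethyl were replaced by hydrogen.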